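Changing the Ring on a Thiocarbonyl Carbon

A few compounds are considered here, and "the series" means these few. Any claim that something is new, unique, unknown or untested is made for them only; others in the source may bear on it.

In a functional assay on KYSE-450 cells (Homo sapiens) for inhibition, read by CCK-8 assay, with a stated time of 48 h (on this read-out higher numbers stand for weaker inhibition and lower numbers for stronger inhibition), compound 1 `COc1ccc(CN(C(=O)CSc2nc3ccccc3o2)c2cc(OC)c(OC)c(OC)c2)cc1` gives 840 nM, compound 2 `CCN1CCN(C(=S)SCC(=O)N(Cc2ccc(OC)cc2)c2cc(OC)c(OC)c(OC)c2)CC1` gives 3070 nM and compound 3 `COc1ccc(CN(C(=O)CSC(=S)N2CCOCC2)c2cc(OC)c(OC)c(OC)c2)cc1` gives 7220 nM. Compound 3 therefore has the highest number of the three and is the weakest inhibitor among them. The unmeasured compound 4 `COc1ccc(CN(C(=O)CSC(=S)N2CCCC2)c2cc(OC)c(OC)c(OC)c2)cc1` differs from it in one place: pyrrolidin-1-yl in place of morpholin-4-yl on a thiocarbonyl carbon. In words, this puts pyrrolidin-1-yl in place of morpholin-4-yl on a thiocarbonyl carbon.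

The closest guide is a 2.4-fold higher number from compound 2 to compound 3 (0.37 log units; beyond the scatter), since that step also changes only the ring on this carbon. The larger steps, an 8.6-fold higher number from compound 1 to compound 3 (0.93 log units; beyond the scatter) and a 3.7-fold higher number from compound 1 to compound 2 (0.56 log units; beyond the scatter), replace the whole group on sulfur and bear on this change only loosely. Within the data shown here, no measured compound carries pyrrolidin-1-yl, so even the direction is uncertain. Morpholin-4-yl does, however, sit with the highest number so far, which points to a modest fall. In this assay the expected step is a 1.8-fold lower number from compound 3 to compound 4 (0.26 log units; within the scatter). For compound 4 the estimate is 4000 nM, with an expected range of 1500 nM to 10000 nM.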

Compound 4, half-maximal inhibitory concentration: 13800 nM
Beside the measured number, compound 4's estimate is 3.5-fold (0.54 log units) below it; measured number above the stated range.
By their numbers in this assay, from the lowest: compound 1; then compound 2; then compounds 3 and 4 (each within the scatter of the next).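

In this assay the step is a 1.9-fold higher number from compound 3 to compound 4 (0.28 log units; within the scatter) and so pyrrolidin-1-yl and morpholin-4-yl cannot be told apart on this thiocarbonyl carbon, even though the ring that enters is five-membered and has no ring oxygen. Measured against 4-ethylpiperazin-1-yl on the same carbon, the step is a 4.5-fold higher number from compound 2 to compound 4 (0.65 log units; beyond the scatter) and measured against the whole group on sulfur in compound 1 it is a 16-fold higher number from compound 1 to compound 4 (1.22 log units; beyond the scatter) and that last step is the only large one in this set. No measurement shown here accounts for these steps.

On these data alone, it remains open whether the ethyl group or the second ring nitrogen of 4-ethylpiperazin-1-yl goes with the lower number of compound 2, which a 4-methylpiperazin-1-yl or piperidin-1-yl ring could test. An open-chain diethylamino group on this carbon also remains untested among the compounds shown.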